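A few compounds are considered here, and "the series" means these few. Any claim that something is new, unique, unknown or untested is made for them only; others in the source may bear on it.

In a functional assay on KARPAS-422 cells (Homo sapiens) for antiproliferative activity, read by resazurin assay, with a stated time of 72 h (a higher number here means a weaker inhibitor, a lower number a stronger inhibitor), compound 1 `Cc1cc(C)c(CN2CCc3c(Cl)cc([C@H](CO)[C@H]4CCOC4)c(Cl)c3C2=O)c(=O)[nH]1` gives 15 nM, the lower of the two single numbers available. Compound 2 `COc1cc(C)[nH]c(=O)c1CN1CCc2c(Cl)cc([C@H](O)C3COC3)c(Cl)c2C1=O` gives 108 nM, a gap from compound 1 that lies beyond the scatter. Compound 3 `CCOC(c1cc(Cl)c2c(c1Cl)C(=O)N(Cc1c(C)cc(C)[nH]c1=O)CC2)C1CS(=O)(=O)C1` has no single number: compound 3 stands at 5560 nM; 34 nM (2 entries), and entries this far apart do not fix its rank.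

Compound 4 `Cc1cc(C)c(CN2CCc3c(Cl)cc([C@@H](C)CO)c(Cl)c3C2=O)c(=O)[nH]1` differs from compound 1 in one place, with methyl in place of oxolan-3-yl on a saturated chain carbon bound to an aromatic carbon and a saturated chain carbon. Going by the values given here, no measured pair isolates this change, so the expectation is a judgement. With compound 1 at 15 nM, a higher number in this assay is expected to be more likely than a lower one, and the rise is expected to lie beyond the scatter. The estimate amounts to a 4.7-fold higher number from compound 1 to compound 4 (0.67 log units; beyond the scatter). For compound 4 the estimated value is 70 nM, with an expected range of 18 nM to 300 nM.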

Compound 4, half-maximal inhibitory concentration: 1500 nM
Beside the measured number, compound 4's estimate is 21-fold (1.33 log units) below it; measured number outside the range, above it.
By their numbers in this assay, from the lowest: compound 1; then compound 2; then compound 4.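

In this assay, methyl in place of oxolan-3-yl on a saturated chain carbon bound to an aromatic carbon and a saturated chain carbon gives a 100-fold higher number from compound 1 to compound 4 (2.00 log units; beyond the scatter). Going by these compounds alone, this is the first change that can be read in one place, and it shows that the number at this position depends strongly on the substituent, with the loss of the oxolan-3-yl ring and its defined stereocentre costing far more than the scatter. No measurement shown bears on why the step is this large.

The compounds shown do not separate the contribution of the ring from that of its oxygen, a question that a cyclopentyl group or an ethyl chain on the same carbon would address. Going by these compounds, the role of the stereocentre within oxolan-3-yl also remains open, as the opposite configuration does not appear among them.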